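Swapping an oxy group for a carboxymethyl amino group

This account rests on a few compounds, and the source may have more. Where it says the series, first, only, none or still open, it means among the compounds named here.

In a functional assay on PC-3 cells (Homo sapiens), read by MTT assay, with a stated time of 48 h (on this read-out higher numbers stand for weaker inhibition and lower numbers for stronger inhibition), compound 1 (`CCn1c(C(=O)NCCN(C)C)ccc1C(CC)(CC)c1ccc(OCC(O)C(C)(C)C)c(C)c1`) gives 1630 nM and compound 2 (`CCn1c(C(=O)N(C)CCC#N)ccc1C(CC)(CC)c1ccc(OCC(O)C(C)(C)C)c(C)c1`) gives 1700 nM. The step between these two is a 1.0-fold higher number from compound 1 to compound 2 (0.02 log units; within the scatter). Compound 3 (`C#CC(C)OC(=O)c1ccc(C(CC)(CC)c2ccc(OCC(O)C(C)(C)C)c(C)c2)n1CC`) gives 38200 nM, the highest number of the three and thus the weakest inhibition.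

Compound 4 (`CCn1c(C(=O)N(C)CC(=O)O)ccc1C(CC)(CC)c1ccc(OCC(O)C(C)(C)C)c(C)c1`) has not yet been measured. It shares its core with compound 3 and differs on a carbonyl carbon, with (carboxymethyl)(methyl)amino in place of (1-methylprop-2-yn-1-yl)oxy on a carbonyl carbon.

Among the compounds with values here, two measured steps bear on this change: a 23-fold higher number from compound 1 to compound 3 (1.37 log units; beyond the scatter) and a 22-fold higher number from compound 2 to compound 3 (1.35 log units; beyond the scatter). Both are large, and each puts the same (1-methylprop-2-yn-1-yl)oxy in place of an amino group on that carbonyl carbon. Within the data shown here, no measured compound carries the carboxymethyl group, so the reverse step in this assay is expected to point to a lower number, perhaps with a somewhat smaller size. The expected change is a 13-fold lower number from compound 3 to compound 4 (1.10 log units; beyond the scatter). For compound 4, the estimated value is 3000 nM, with an expected range of 700 nM to 20000 nM.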

Compound 4, half-maximal inhibitory concentration: 23900 nM
Compound 4: the middle estimate sits 8.0-fold (0.90 log units) below what was measured, and the stated range ends below it.
By their numbers in this assay, from the lowest: compounds 1 and 2 (each within the scatter of the next); then compounds 4 and 3 (each within the scatter of the next).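

In this assay, an amino group on the carbonyl carbon does not by itself keep the lower numbers of compounds 1 and 2, since (carboxymethyl)(methyl)amino gives large steps upward (a 15-fold higher number from compound 1 to compound 4 (1.17 log units; beyond the scatter); a 14-fold higher number from compound 2 to compound 4 (1.15 log units; beyond the scatter)). The second of these steps changes only carboxy for cyanomethyl on a saturated chain carbon bound to an amide-type nitrogen, and it shows that this end of the chain alone can separate the amides. Compound 4 stands level with the (1-methylprop-2-yn-1-yl)oxy compound (a 1.6-fold lower number from compound 3 to compound 4 (0.20 log units; within the scatter)), and no measurement at hand accounts for this.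

Still open, on these data alone, is whether a methyl ester or a primary amide in place of the carboxylic acid would return to the level of compound 2. As far as these compounds go, it is equally open whether a longer chain carrying the carboxylic acid would do so.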